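A chlorine on the core phenyl of compound 2

This account rests on a few compounds, and the source may have more. Where it says the series, first, only, none or still open, it means among the compounds named here.

Compound 2 `COc1ccc(Cn2cc(CNC(=O)c3cn(-c4ccccc4)nc3-c3ccccc3)nn2)cc1OC` was tested in a functional assay on MIA PaCa-2 cells (Homo sapiens) for antiproliferative activity, read by sulforhodamine B assay, with a stated time of 48 h (on this read-out lower numbers stand for stronger inhibition of growth and higher numbers for weaker inhibition of growth), and gives 8200 nM. Among the three measured compounds it stands second highest: compound 1 `O=C(NCc1cn(Cc2ccc(Cl)cc2)nn1)c1cn(-c2ccccc2)nc1-c1ccccc1` gives 8700 nM, so that a 1.1-fold lower number from compound 1 to compound 2 (0.03 log units; within the scatter), whereas compound 3 `COc1cc(Cn2cc(CNC(=O)c3cn(-c4ccccc4)nc3-c3ccccc3)nn2)cc(OC)c1` gives 190 nM, and a 43-fold lower number from compound 2 to compound 3 (1.64 log units; beyond the scatter). Likewise a 46-fold lower number from compound 1 to compound 3 (1.66 log units; beyond the scatter). All three measured steps concern the aryl group on the saturated chain carbon bound to an aromatic nitrogen; none touches the phenyl attached to the shared core. Compound 4 `COc1ccc(Cn2cc(CNC(=O)c3cn(-c4ccccc4)nc3-c3ccc(Cl)cc3)nn2)cc1OC` differs from compound 2 by chloro in place of hydrogen on an aromatic carbon. Going by the values given here, no measured pair shows what this change does in this assay, so there is no ground for expecting a shift beyond the scatter in either direction, and compound 4 is expected to sit close to compound 2. The estimate for compound 4 in this assay is 8000 nM, with a range from 2000 nM to 32000 nM. This estimate means an expected step of a 1.0-fold lower number from compound 2 to compound 4 (0.01 log units; within the scatter).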

Compound 4, concentration for 50% growth inhibition: 9400 nM
The estimate for compound 4 lay 1.2-fold (0.07 log units) below the measured number, within the range that was stated.
By their numbers in this assay, from the lowest: compound 3; then compounds 2, 1 and 4 (each within the scatter of the next).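

In this assay, going by these compounds alone, chloro in place of hydrogen on the phenyl attached to the shared core, para to a large group, gives a 1.1-fold higher number from compound 2 to compound 4 (0.06 log units; within the scatter) and so gives the first measured reading at this position. On the background of compound 2, the change from phenyl to 4-chlorophenyl therefore does not separate the two compounds, whereas the aryl group on the chain carbon does, with a 43-fold lower number from compound 2 to compound 3 (1.64 log units; beyond the scatter) as its largest step from compound 2. No supporting measurement bears on this result.

Only one substituent at one place on this phenyl is shown, so what an amine or a carboxylic acid would do there remains open. Also open, as far as these compounds go, is whether chloro at this place would leave the number of compound 3, 190 nM, within the scatter as well.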